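A few compounds are considered here, and "the series" means these few. Any claim that something is new, unique, unknown or untested is made for them only; others in the source may bear on it.

Compound 1 `CCOC(=O)/C=C/C1=CC[C@H]2C(C)(C)CCC[C@]2(C)[C@H]1C=O`: 29000 nM
Compound 2 `CC(C)(C)OC(=O)/C=C/C1=CC[C@H]2C(C)(C)CCC[C@]2(C)[C@H]1C=O`: 29000 nM
Compound 3 `COC(=O)/C=C/C=C/C1=CC[C@H]2C(C)(C)CCC[C@]2(C)[C@H]1C=O`: 12000 nM

In a functional assay on Hs 683 cells (Homo sapiens) for inhibition, read by MTT assay, with a stated time of 72 h (a lower number here means a stronger inhibitor of growth, a higher number a weaker inhibitor of growth), compound 3 has the lowest number of the three. Compound 4 `CC(=O)/C=C/C1=CC[C@H]2C(C)(C)CCC[C@]2(C)[C@H]1C=O` differs from compound 3 by one change: acetyl in place of 2-(methoxycarbonyl)ethenyl on a double-bonded chain carbon bound to a double-bonded chain carbon. Like compound 1 and compound 2, compound 4 lacks the ethenyl part of the group that leaves. Two measured steps therefore bear most directly on it: a 2.4-fold lower number from compound 1 to compound 3 (0.38 log units; beyond the scatter) and a 2.4-fold lower number from compound 2 to compound 3 (0.38 log units; beyond the scatter). Reversing that gain points to a higher number. The third step, no change at the digits printed from compound 1 to compound 2 (within the scatter), shows that one change in the ester made no difference. Within the data shown here, no measured compound carries acetyl itself, so the estimate stays loose. The expected change is modest: a 2.1-fold higher number from compound 3 to compound 4 (0.32 log units; beyond the scatter). For compound 4 the estimated value is 25000 nM, with an expected range from 11000 nM to 55000 nM.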

Compound 4, concentration for 50% growth inhibition: 22000 nM
Compound 4: the middle estimate sits 1.1-fold (0.06 log units) above what was measured; low and high end bracket the measured number.
By their numbers in this assay, from the lowest: compounds 3, 4, 1 and 2 (each within the scatter of the next, the first and the last beyond it).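

Acetyl on a double-bonded chain carbon bound to a double-bonded chain carbon stays within the scatter in this assay when compared with the ethyl ester (a 1.3-fold lower number from compound 1 to compound 4 (0.12 log units; within the scatter)), the tert-butyl ester (a 1.3-fold lower number from compound 2 to compound 4 (0.12 log units; within the scatter)) and the longer compound 3 (a 1.8-fold higher number from compound 3 to compound 4 (0.26 log units; within the scatter)). Methyl on this carbonyl carbon therefore serves as well as ethoxy or tert-butoxy, so the ester oxygen is not required at this level of growth inhibition. No available evidence accounts for this result. From the compounds shown here alone, whether an amide or a carboxylic acid at this place would hold the same level remains open.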